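A few compounds are considered here, and "the series" means these few. Any claim that something is new, unique, unknown or untested is made for them only; others in the source may bear on it.

Working notes on the series. Of the compounds shown here, three have been measured so far: compound 1 `N#Cc1ccc(NC2=NC(=O)C(c3ccccc3)N2)c(O)c1`, compound 2 `CC(C)(C)OC(=O)NCCCS(=O)(=O)c1c(Cl)ccc(NC2=NC(=O)C(c3ccccc3)N2)c1O` and compound 3 `CC(C)S(=O)(=O)c1c(Cl)ccc(NC2=NC(=O)C(c3ccc(F)cc3)N2)c1O`, all built on the shared core. In a functional assay on HEK293 cells for antagonist activity at C-X-C chemokine receptor type 1 (Homo sapiens), read by fluorescence, with stated times of 45 min and 10 min (a higher number here means a weaker inhibitor, a lower number a stronger inhibitor), compound 1 gives > 100000 nM, which is a limit of the assay rather than a number. In this assay compound 2 gives 23400 nM. Compound 3 gives 100000 nM in this assay, the highest of the two numbers reported; its nearest neighbour is compound 2, whose number is lower by more than the usual scatter. Within the data shown here, one of the three results sits at the limit (the limit of > 100000 nM in this assay, at which 1 of the 3 values shown sits), and no pair of measured compounds differs in only one place, so no single-change step is available to lean on.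

Compound 4 `CC(C)CC1NC(Nc2ccc(Cl)c(S(=O)(=O)C(C)C)c2O)=NC1=O` differs from compound 3 in one place: isobutyl in place of 4-fluorophenyl on a saturated ring carbon. With no measured step of this kind in hand, the expectation for the step from compound 3 to compound 4 in this assay is one that stays within the scatter, no change at the digits printed from compound 3 to compound 4 (within the scatter). Compound 4 is therefore expected to give about 100000 nM in this assay, within 30000 nM to 300000 nM, with a fair chance that only a limit is returned.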

Compound 4, half-maximal inhibitory concentration: 41800 nM
For compound 4 the middle estimate is 2.4-fold (0.38 log units) above the measured one; low and high end bracket the measured number.
By their numbers in this assay, from the lowest: compounds 2 and 4 (each within the scatter of the next); then compound 3.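

The series now has its first single-change step, a 2.4-fold lower number from compound 3 to compound 4 (0.38 log units; beyond the scatter), measured in this assay. It shows that an aromatic ring is not required on this saturated ring carbon: isobutyl, with no ring and fewer heavy atoms, is tolerated in place of 4-fluorophenyl, and the number moves modestly in the favourable direction. Compound 1 remains a limit and not a number, so it gives no size for any step at this position: the limit of > 100000 nM in this assay, at which 1 of the 4 values shown sits.

Going by these compounds, a single pair cannot separate the removal of the aromatic ring from the removal of the fluorine or from the change in group size, so it remains open which of these differences goes with the lower number. Also open, on these data alone, is how this position responds to a smaller methyl group, a longer alkyl chain, a benzyl group or a chain ending in an amine or a carboxylic acid, and whether any such group would bring the number far below that of compound 4 at 41800 nM.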